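The source may report more compounds than this note shows. Statements on the series, on what has been measured and on what is new or still open speak of the compounds shown alone.

Measured in a physicochemical assay for lipophilicity, read by HPLC, at pH 7.4; a lower number here means a more polar compound, a higher number a more lipophilic compound:
- Compound 1 `CCOC(=O)COc1ccc([C@H]2CC[C@]3(CC2)OOC2(O3)C3CC4CC(C3)CC2C4)cc1`: > 5.3, a limit of the assay and not a number.
- Compound 2 `O=C(O)CCCCOc1ccc([C@H]2CC[C@]3(CC2)OOC2(O3)C3CC4CC(C3)CC2C4)cc1`: 4.
- Compound 3 `CC(C)(Oc1ccc([C@H]2CC[C@]3(CC2)OOC2(O3)C3CC4CC(C3)CC2C4)cc1)C(=O)O`: 3.1.

Compound 3 holds the lower of the two actual numbers. The gap between them is a number 0.90 log units lower from compound 2 to compound 3 (beyond the scatter).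

In compound 4 `O=C(O)c1ccc([C@H]2CC[C@]3(CC2)OOC2(O3)C3CC4CC(C3)CC2C4)cc1`, carboxy stands in place of 1-carboxy-1-methylethoxy on an aromatic carbon, para to a large group (carboxy in place of 1-carboxy-1-methylethoxy on an aromatic carbon).

Within the data shown here, the closest precedent is a number 0.90 log units lower from compound 2 to compound 3 (beyond the scatter), the only measured step between two acids, where a smaller acid group takes the place of a larger one. The steps of a number at least 1.30 log units lower from compound 1 to compound 2 (beyond the scatter) and a number at least 2.20 log units lower from compound 1 to compound 3 (beyond the scatter) start from a limit and bear less.

A modest fall is therefore expected, and the expected step is a number 0.60 log units lower from compound 3 to compound 4 (beyond the scatter). For compound 4 the estimated value is 2.5, with an expected range of 1.8 to 3.2.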

Compound 4, distribution coefficient: 3
Beside the measured number, compound 4's estimate is 0.50 log units below it; measured number inside the range.
By their numbers in this assay, from the lowest: compounds 4 and 3 (each within the scatter of the next); then compound 2. At a limit, above all of these: compound 1.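

Carboxy in place of 1-carboxy-1-methylethoxy on this aromatic carbon gives a number 0.10 log units lower from compound 3 to compound 4 (within the scatter), so shortening the group that carries the acid need not shift the reading in this assay. Carboxy in place of 4-carboxybutoxy still gives a number 1.00 log units lower from compound 2 to compound 4 (beyond the scatter), which leaves compound 2 apart from compound 3 and compound 4. For compound 1 the reading is a limit and not a number, and a number at least 2.30 log units lower from compound 1 to compound 4 (beyond the scatter) is only a bound: the limit of > 5.3 in this assay, at which 1 of the 4 values shown sits.

Still open, from the compounds shown here alone, is how an amine or a primary amide on this aromatic carbon would read in this assay. Also open, going by these compounds, is whether an unbranched carboxymethoxy chain would sit with compound 2 or with compound 4.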